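The source may hold more compounds than are shown below. What is called first, only, known or untested is meant among the compounds shown, and "the series" means these compounds.

Within the data shown here, in a functional assay on HeLa cells (Homo sapiens) for antiproliferative activity, read by sulforhodamine B assay, with a stated time of 48 h (on this read-out lower numbers stand for stronger inhibition of growth and higher numbers for weaker inhibition of growth), three related compounds have numbers so far. Compound 1 (`ClC1=C(c2nnc(-c3ccccc3)o2)CCCc2ccccc21`) gives 3220 nM and compound 2 (`Cc1cc2c(cc1C)C(Cl)=C(c1nnc(-c3ccccc3)o1)CCC2`) gives 4680 nM in the same test, so these two lie within the usual scatter of each other. Compound 3 (`COc1ccc([N+](=O)[O-])c(-c2nnc(C3=C(Cl)c4cc(C)c(C)cc4CCC3)o2)c1OC`) has several further groups on the aromatic ring where compound 2 has a plain phenyl. Compound 3 gives 310 nM as its number, which is lower than that of compound 2 by a margin well beyond the scatter. Compound 2 therefore stands level with compound 1 and well above compound 3 on this scale.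

Compound 4 (`Cc1cc2c(cc1C)C(Cl)=C(c1nnc(-c3cccc(Cl)c3)o1)CCC2`) is compound 2 with a single change: chloro in place of hydrogen on an aromatic carbon, which turns the phenyl into 3-chlorophenyl. Among the measured compounds shown here, no measured pair shows this change alone, so the expectation is loose. For the measured compounds named here, the only hint is compound 3 at 310 nM in this assay, which pairs a substituted ring with a lower number, though its groups are quite unlike a single chloro. A small move toward stronger inhibition of growth is expected, perhaps hardly beyond the scatter, and the estimated step is a 1.8-fold lower number from compound 2 to compound 4 (0.26 log units; within the scatter) in size. For compound 4 the estimated value is 2600 nM and is expected to fall from 1000 nM to 6000 nM in repeat measurements.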

Compound 4, concentration for 50% growth inhibition: 5940 nM
Estimate against measurement, compound 4: 2.3-fold (0.36 log units) below; the range from low to high includes it.
By their numbers in this assay, from the lowest: compound 3; then compounds 1, 2 and 4 (each within the scatter of the next).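

In this assay, chloro in place of hydrogen on an aromatic carbon, meta to a large group, gives a 1.3-fold higher number from compound 2 to compound 4 (0.10 log units; within the scatter), so the number stays level within the usual scatter. Among these compounds, until this pair, no two measured compounds differed in one place only, so no single group on this ring could be read on its own; now one place on the ring has a direct reading for one group, and phenyl and 3-chlorophenyl cannot be told apart on this scale. Nothing available here explains why the two numbers stay level.

A single chloro at a single place says nothing about the same atom elsewhere on the ring, or about quite different groups at this place, such as an amine or a carboxylic acid. Going by these compounds, compound 3 differs from compound 2 by several groups at once, so it remains open which of those groups, alone or together, goes with the lower number of compound 3.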